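Swapping the anilide aryl group on a second core

The source may report more compounds than this note shows. Statements on the series, on what has been measured and on what is new or still open speak of the compounds shown alone.

Measured compounds:
- compound 1, `CC(=O)Nc1n[nH]c2cc(-c3cn([C@@H]4CN[C@H](C(=O)Nc5ccc(Cl)c(C(F)(F)F)c5)C4)nn3)ccc12`, 15500 nM
- compound 2, `CC(=O)Nc1n[nH]c2cc(-c3cn([C@@H]4CN[C@H](C(=O)Nc5ccc(Cl)cc5Cl)C4)nn3)ccc12`, 2090 nM
- compound 3, `CC(C)(C)OC(=O)N1C[C@@H](n2cc(-c3ccc4nc(N)sc4n3)nn2)C[C@H]1C(=O)Nc1ccc(Cl)c(C(F)(F)F)c1`, 10900 nM

Compound 1 and compound 2 share one core; compound 3 sits on a different core, and the difference between the two cores is not broken down here. Compound 4, `CC(C)(C)OC(=O)N1C[C@@H](n2cc(-c3ccc4nc(N)sc4n3)nn2)C[C@H]1C(=O)Nc1ccc(Cl)cc1Cl`, is not yet measured.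

In a functional assay on K562 cells (Homo sapiens) for inhibition, read by MTT assay, with a stated time of 48 h (on this read-out higher numbers stand for weaker inhibition and lower numbers for stronger inhibition), compound 2 gives 2090 nM, and the step of a 7.4-fold lower number from compound 1 to compound 2 (0.87 log units; beyond the scatter) comes from the change (2,4-dichlorophenyl in place of 4-chloro-3-(trifluoromethyl)phenyl on an amide-type nitrogen). The same kind of change is now made on the other core, from compound 3 to compound 4: 2,4-dichlorophenyl in place of 4-chloro-3-(trifluoromethyl)phenyl on an amide-type nitrogen. Compound 3 gives 10900 nM in this assay, close to compound 1.

Whether the change carries over to the second core cannot be checked from the compounds here; the change has been seen on one core only. The expectation rests on that single step. Within the data shown here, compound 4 is expected to give 2000 nM, with a plausible range from 600 nM to 7000 nM, which means an expected step of a 5.5-fold lower number from compound 3 to compound 4 (0.74 log units; beyond the scatter), set a little smaller than the measured one because of a 7.4-fold lower number from compound 1 to compound 2 (0.87 log units; beyond the scatter) being the only guide.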

Compound 4, half-maximal inhibitory concentration: 8940 nM
Compound 4: middle estimate off by 4.5-fold (0.65 log units), on the low side, and the stated range ends below it.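

In this assay, the swap to 2,4-dichlorophenyl on the core of compound 3 gives a 1.2-fold lower number from compound 3 to compound 4 (0.09 log units; within the scatter), so on this core it produces no difference that can be told from the scatter. The result does not match the step seen on the core of compound 1, and the two steps differ: the same change on two cores in this assay, a 7.4-fold lower number (0.87 log units; beyond the scatter) from compound 1 to compound 2 and a 1.2-fold lower number (0.09 log units; within the scatter) from compound 3 to compound 4, 6.1-fold (0.78 log units) apart, beyond the scatter of two such steps These two pairs show that the size of this step depends on the core, so the step from one core cannot be carried over to the other in this series, but they do not show how the change would behave on any further core.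

The compounds shown leave open which of the differences between the two cores sets the size of the step, for example whether the tert-butyl carbamate on the core of compound 3 plays any part. They also leave open how other groups on the amide-type nitrogen, such as a phenyl ring bearing a nitrile or a carboxylic acid, would compare across both cores.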